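Three inactive analogues and a dichlorophenyl variant

A few compounds are considered here, and "the series" means these few. Any claim that something is new, unique, unknown or untested is made for them only; others in the source may bear on it.

Compound 1 `Fc1ccc(-c2cn3nc(Cc4ccc(Cl)cc4)sc3n2)cc1` — > 250000 nM
Compound 2 `Clc1ccc(Cc2nn3cc(-c4ccc(Br)cc4)nc3s2)cc1` — > 250000 nM
Compound 3 `Cc1ccc(-c2cn3nc(Cc4ccc(Cl)cc4)sc3n2)cc1` — > 250000 nM

In a functional assay on HeLa cells (Homo sapiens) for cytotoxicity, with a stated time of 72 h (on this read-out lower numbers stand for stronger inhibition and higher numbers for weaker inhibition), compound 1 gives only a limit, > 250000 nM. In this assay compound 2 likewise gives only a limit, > 250000 nM. For compound 3 this assay again reports only a limit, > 250000 nM. All three values therefore sit at the limit of > 250000 nM in this assay, at which 3 of the 3 values shown sit, and none of the three measured steps can be read: a step that the two limits leave unreadable from compound 1 to compound 2, a step that the two limits leave unreadable from compound 1 to compound 3 and a step that the two limits leave unreadable from compound 2 to compound 3.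

Compound 4 `Clc1ccc(Cc2nn3cc(-c4ccc(Cl)cc4Cl)nc3s2)cc1` has not been measured in this assay. It differs from compound 1 by 2,4-dichlorophenyl in place of 4-fluorophenyl on an aromatic carbon. The three measured steps bear on it only in that each exchange of the group on that aromatic carbon, whether to bromo or to methyl, left the compound at the limit, so they give no direction and no size for a further exchange to 2,4-dichlorophenyl.

On this basis compound 4 is expected to remain at the limit as well, with the step from compound 1 to compound 4 estimated as a step that the limit leaves unreadable from compound 1 to compound 4. The estimate for compound 4 in this assay is 300000 nM, with a range from 100000 nM to 1000000 nM, and most likely the assay will again report only a limit.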

Compound 4, half-maximal inhibitory concentration: 109000 nM
Compound 4: middle estimate off by 2.8-fold (0.44 log units), on the high side, and the stated range covers the measured number.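

In this assay, this aromatic carbon, next to the ring nitrogen, now shows that a change there can move the read-out: 2,4-dichlorophenyl gives an at least 2.2-fold lower number from compound 1 to compound 4 (0.36 log units; beyond the scatter), an at least 2.2-fold lower number from compound 3 to compound 4 (0.36 log units; beyond the scatter) and an at least 2.2-fold lower number from compound 2 to compound 4 (0.36 log units; beyond the scatter). For the compounds shown here, the steps among compound 1, compound 2 and compound 3 cannot be read, so these three steps are the first readable ones at this position, and each is a lower bound on the change because it starts from a compound whose value is only a limit. Compound 4 is the only compound shown with a number rather than a limit, and the others stay where they were: the limit of > 250000 nM in this assay, at which 3 of the 4 values shown sit.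

The compounds shown leave open whether a single chlorine on the phenyl ring would give the same step, and whether a phenyl ring carrying an amine or a carboxylic acid would lower the number further. What lies behind the step cannot be told from these values.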